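The compounds below may be only part of what the source reports. "The series", "measured", "known", "first", "only" and "open" are said of these compounds alone.

Compound 1 `C=C1CC[C@@H]2[C@](C)(CO)[C@H](O)CC[C@@]2(C)[C@@H]1CCC1=CCOC1=O` gives "not active" (no number reported) in a functional assay on MDA-MB-231 cells (Homo sapiens) for cytotoxicity, read by MTT assay, with a stated time of 48 h; on this read-out lower numbers stand for stronger inhibition and higher numbers for weaker inhibition.
Compound 2 `C=C1CC[C@@H]2[C@](C)(COC(=O)COc3ccccc3)[C@H](O)CC[C@@]2(C)[C@@H]1CCc1ccoc1` gives 35000 nM in this assay.
Compound 3 `C[C@]1(CO)[C@H]2CCC(=O)[C@@H](CCc3ccoc3)[C@]2(C)CC[C@H]1O` gives 56300 nM in this assay.

Among the compounds with values here, compound 1 stands with no single number: it is reported only as not active, so no step from it to any measured compound can be sized. Compounds 2 and 3, which both carry a furan, give values within the usual scatter of one another, so neither is called stronger. Compound 4 `C=C1CC[C@@H]2[C@](C)(CO)[C@H](O)CC[C@@]2(C)[C@@H]1CC(O)c1ccoc1` differs from compound 1 by a group of 7 heavy atoms (5 carbon, 2 oxygen; one five-membered aromatic ring with 1 hetero atom) in place of a group of 7 heavy atoms (5 carbon, 2 oxygen; one five-membered non-aromatic ring with 1 hetero atom), on a saturated chain carbon bound to a saturated ring carbon. Within the data shown here, no measured pair shows this change, so its size cannot be read from the data, and only a weak result is expected, because compound 1 gives "not active" (no number reported) and compound 3 gives 56300 nM. Compound 4 is expected to give 50000 nM in this assay, with a range from 15000 nM to 200000 nM.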

Compound 4, half-maximal inhibitory concentration: > 100000 nM
Compound 4: a limit, no number; the forecaster's own chance of this, stated with the estimate: 45%; middle value at least 2.0-fold (0.30 log units) from the limit.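

Neither compound 1 nor compound 4 has a single number, so no step can be read between them. Compound 4 gives > 100000 nM in this assay, which is a limit. From the compounds shown here alone, how much the (furan-3-yl)(hydroxy)methyl group changes activity remains open.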